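The source may hold more compounds than are shown below. What is called first, only, known or untested is meant among the compounds shown, and "the series" means these compounds.

Series notes. For the measured compounds named here, compound 1 `C/C=C(\C)[C@H]1OC(=O)[C@@H](C)NC(=O)[C@H]([C@@H](C)CC)NC(=O)CN(C)C(=O)[C@@H](Cc2ccccc2)N(C)C(=O)[C@H](C)NC(=O)[C@@H](CC(C)C)OC(=O)/C(C)=C/C[C@H](O)[C@@H]1C` is the reference macrocycle; in a functional assay on K562 cells (Homo sapiens) for cytotoxicity, read by CellTiter-Blue, with a stated time of 72 h (a lower number here means a stronger inhibitor, a higher number a weaker inhibitor), compound 1 gives 0.0031 nM, the lowest of the two numbers so far. Its companion compound 2 `C/C=C(\C)[C@H]1OC(=O)[C@@H](C)NC(=O)[C@H]([C@@H](C)CC)NC(=O)CN(C)C(=O)[C@@H](Cc2ccccc2)N(C)C(=O)[C@H](C)NC(=O)[C@@H](CC(C)C)OC(=O)/C(C)=C/C[C@H](OCSC)[C@@H]1C` carries (methylsulfanyl)methyl in place of hydrogen on an oxygen on a saturated carbon; in this assay compound 2 gives 0.0063 nM, and the step between them is a 2.0-fold higher number from compound 1 to compound 2 (0.31 log units; beyond the scatter). Compound 3 `C/C=C(\C)[C@H]1OC(=O)[C@@H](C)NC(=O)[C@H]([C@@H](C)CC)NC(=O)CN(C)C(=O)[C@@H](Cc2ccc(Cl)cc2)N(C)C(=O)[C@H](C)NC(=O)[C@@H](CC(C)C)OC(=O)/C(C)=C/C[C@H](O)[C@@H]1C` differs from compound 1 at a different site: chloro in place of hydrogen on an aromatic carbon. Going by the values given here, no measured step touches the aromatic ring, so the single step from compound 1 to compound 2 bears on this change only loosely, as an example of one small group added elsewhere on the shared core moving the number modestly. The step from compound 1 to compound 3 in this assay is therefore expected to be small, possibly within the scatter, with no direction clearly indicated: a 1.1-fold higher number from compound 1 to compound 3 (0.05 log units; within the scatter). The number for compound 3 is estimated at 0.0035 nM, within 0.0012 nM to 0.01 nM.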

Compound 3, half-maximal inhibitory concentration: 0.000011 nM
The estimate for compound 3 lay 320-fold (2.50 log units) above the measured number, outside the stated range (below it).
By their numbers in this assay, from the lowest: compound 3; then compound 1; then compound 2.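

In this assay, chloro in place of hydrogen on an aromatic carbon, para to a large group, gives a 280-fold lower number from compound 1 to compound 3 (2.45 log units; beyond the scatter). This single added heavy atom on the six-membered aromatic ring produces a large step, whereas the (methylsulfanyl)methyl group on the oxygen gives only a 2.0-fold higher number from compound 1 to compound 2 (0.31 log units; beyond the scatter), in the opposite direction. The benzyl position is therefore far more responsive in this series than the earlier pair could show, and no supporting data are available to account for the size of the step.

With only hydrogen and chloro at this place, the compounds shown cannot tell whether the drop is specific to chloro or would also appear with fluoro, bromo, methoxy or an amine. Also open, going by these compounds, is whether it would persist in combination with the (methylsulfanyl)methyl group on the oxygen.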